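Removing one methoxy group: a matched pair repeated

A few compounds are considered here, and "the series" means these few. Any claim that something is new, unique, unknown or untested is made for them only; others in the source may bear on it.

Compound 1 `COc1cc(-c2nc3cc(/C=C4\SC(=O)NC4=O)ccc3[nH]2)cc(OC)c1OC` and compound 2 `COc1ccc(-c2nc3cc(/C=C4\SC(=O)NC4=O)ccc3[nH]2)cc1OC` differ in a single place. In a functional assay on HT-1080 cells (Homo sapiens) for inhibition, read by MTT assay, with a stated time of 48 h (on this read-out lower numbers stand for stronger inhibition and higher numbers for weaker inhibition), compound 1 gives 3120 nM and compound 2 gives 2430 nM, with a 1.3-fold lower number from compound 1 to compound 2 (0.11 log units; within the scatter). The change is hydrogen in place of methoxy on an aromatic carbon. Compound 3 `COc1cc(CN2C(=O)S/C(=C\c3ccc4[nH]c(-c5cc(OC)c(OC)c(OC)c5)nc4c3)C2=O)cc(OC)c1OC` carries a further substituent on the ring-fused part; the difference between its core and that of compound 1 is not broken down here. In this assay compound 3 gives 980 nM, a number lower than those of compound 2 and compound 1 by margins beyond the scatter. Compound 4 `COc1ccc(-c2nc3cc(/C=C4\SC(=O)N(Cc5cc(OC)c(OC)c(OC)c5)C4=O)ccc3[nH]2)cc1OC` has not yet been measured. It differs from compound 3 by hydrogen in place of methoxy on an aromatic carbon, the same change that takes compound 1 to compound 2, at a place described in identical terms. Among the compounds with values here, the step from compound 3 to compound 4 in this assay is expected to be a 1.2-fold lower number from compound 3 to compound 4 (0.06 log units; within the scatter), because the only precedent is a 1.3-fold lower number from compound 1 to compound 2 (0.11 log units; within the scatter) and lies within the scatter. Compound 4 is therefore estimated to give about 850 nM in this assay, with a likely range from 420 nM to 1700 nM.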

Compound 4, half-maximal inhibitory concentration: 270 nM
For compound 4 the middle estimate is 3.1-fold (0.50 log units) above the measured one, outside the stated range (below it).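

In this assay, going from 3,4,5-trimethoxyphenyl to 3,4-dimethoxyphenyl on the core of compound 3 gives a 3.6-fold lower number from compound 3 to compound 4 (0.56 log units; beyond the scatter), and the change does not carry over at one size between the two cores: the same change on two cores in this assay, a 1.3-fold lower number (0.11 log units; within the scatter) from compound 1 to compound 2 and a 3.6-fold lower number (0.56 log units; beyond the scatter) from compound 3 to compound 4, 2.8-fold (0.45 log units) apart, beyond the scatter of two such steps

The step on the core of compound 1 lies within the scatter, and only on the core of compound 3 does this change produce a step beyond it. With a single pair on each core, the data show that the size of this step depends on its core in this series, but they do not show why, nor whether the further substituent shared by compound 3 and compound 4 accounts for the gap.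

On these data alone, how a hydroxy group or a fluorine atom at the same place would compare with methoxy and hydrogen remains open. As far as these compounds go, it is also open whether an amine or a carboxylic acid in place of that further substituent would keep the larger step or return it to the scatter.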